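From ethyl to methoxymethyl on the shared core

The compounds below may be only part of what the source reports. "The series", "measured", "known", "first", "only" and "open" are said of these compounds alone.

Values in an assay on CHO cells for displacement of a labelled ligand from prostaglandin E2 receptor EP2 subtype (Mus musculus), read by scintillation counting, with a stated time of 60 min; a higher number here means a weaker inhibitor, a lower number a stronger inhibitor:
compound 1, `O=C(O)CCCSCCN1C(=O)OC[C@@H]1/C=C/[C@@H](O)Cc1cccc(C(F)(F)F)c1`: > 10000 nM
compound 2, `O=C(O)CCCSCCN1C(=O)OC[C@@H]1/C=C/[C@@H](O)Cc1cccc(-c2ccccc2)c1`: > 10000 nM
compound 3, `CCc1cccc(C[C@H](O)/C=C/[C@H]2COC(=O)N2CCSCCCC(=O)O)c1`: > 10000 nM

Each of these three values is a limit of the assay, not a number, as the limit of > 10000 nM in this assay, at which 3 of the 3 values shown sit, records. Compound 3 therefore stands at a limit, with nothing to set it apart from the other two. The steps a step that the two limits leave unreadable from compound 1 to compound 2, a step that the two limits leave unreadable from compound 1 to compound 3 and a step that the two limits leave unreadable from compound 2 to compound 3 stay unreadable because the limit of > 10000 nM in this assay, at which 3 of the 3 values shown sit, holds at both ends of each.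

Compound 4, `COCc1cccc(C[C@H](O)/C=C/[C@H]2COC(=O)N2CCSCCCC(=O)O)c1`, differs from compound 3 by methoxy in place of methyl on a saturated chain carbon bound to an aromatic carbon. For the measured compounds named here, no measured step bears readably on this change, so the expected step that the limit leaves unreadable from compound 3 to compound 4 cannot be checked against a limit. Compound 4 is expected to sit at 20000 nM, between 5000 nM and 100000 nM, most likely again as a limit.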

Compound 4, inhibition constant: > 10000 nM
Compound 4 ended at the assay's limit (the forecaster's own chance of this, stated with the estimate: 85%); the middle value does not contradict the limit.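

For the compounds shown here, no step from compound 1, compound 2 or compound 3 to compound 4 can be read: the limit of > 10000 nM in this assay, at which 4 of the 4 values shown sit. The compounds shown leave open how trifluoromethyl, phenyl, ethyl and methoxymethyl compare in this assay.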